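Chloro for Fluoro on Two Differently Arranged Cores

This account rests on a few compounds, and the source may have more. Where it says the series, first, only, none or still open, it means among the compounds named here.

Compound 1: `CS(=O)(=O)c1ccc(F)cc1NCC1=NCCN1`. In an assay on CHO cells for binding affinity to Alpha-2C adrenergic receptor (Homo sapiens), read by radioligand binding (a higher number here means a weaker inhibitor, a lower number a stronger inhibitor), compound 1 gives < 5020 nM, which is a limit of the assay.
Compound 2: `CS(=O)(=O)c1cc(F)ccc1NCC1=NCCN1`. In this assay compound 2 gives < 5020 nM, again a limit.
Compound 3: `CS(=O)(=O)c1ccc(Cl)cc1NCC1=NCCN1`. In this assay compound 3 gives 4790 nM.

Compound 1 and compound 3 differ by chloro in place of fluoro on an aromatic carbon, and the step that the limit leaves unreadable from compound 1 to compound 3 cannot be read, because the limit of < 5020 nM in this assay, at which 2 of the 3 values shown sit, hides its size. Compound 4, `CS(=O)(=O)c1cc(Cl)ccc1NCC1=NCCN1`, is not yet measured; it differs from compound 2 by chloro in place of fluoro on an aromatic carbon. This is the same kind of change, but the surroundings differ: in compound 4 the chloro sits meta to a methylsulfonyl group and para to a group of 7 heavy atoms, whereas in compound 3 it sits meta to the group of 7 heavy atoms and para to the methylsulfonyl group. How the cores of compound 1 and compound 2 differ is not broken down here. With only an unreadable step to lean on, the expected step from compound 2 to compound 4 is modest, a step that the limit leaves unreadable from compound 2 to compound 4. Compound 4 is estimated at 4000 nM, between 1500 nM and 12000 nM.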

Compound 4, inhibition constant: 3980 nM
Beside the measured number, compound 4's estimate is 1.0-fold (0.00 log units) above it, within the range that was stated.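

The size of the step between compound 2 and compound 4 cannot be read, because the value of compound 2 is only a limit: the limit of < 5020 nM in this assay, at which 2 of the 4 values shown sit.

The compounds shown leave open whether chloro in place of fluoro changes the result in this assay on either core.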